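A few compounds are considered here, and "the series" means these few. Any claim that something is new, unique, unknown or untested is made for them only; others in the source may bear on it.

Measured in an ADME assay on microsomes from liver (Rattus norvegicus) for metabolic stability, using NADPH, with a stated time of 10 min; on this read-out higher numbers stand for a more stable compound and lower numbers for a less stable compound:
compound 1 `CN(C[C@H]1Cc2c(cccc2N2CCC(N)CC2)CN1)[C@H]1CCCc2cccnc21`: 38.4%
compound 2 `CN(C[C@H]1Cc2c(cccc2N2C[C@H]3CNC[C@H]3C2)CN1)[C@H]1CCCc2cccnc21`: 38.1%

The two numbers lie within the scatter of each other, so compound 2, at 38.1%, stands level with compound 1. Compound 3 `CN(C)[C@H]1CCN(c2cccc3c2C[C@H](CN(C)[C@H]2CCCc4cccnc42)NC3)C1` differs from compound 2 in one group: a group of 8 heavy atoms (6 carbon, 2 nitrogen; one five-membered non-aromatic ring with 1 hetero atom) in place of a group of 8 heavy atoms (6 carbon, 2 nitrogen; 2 five-membered non-aromatic rings with 1 hetero atom each), on an aromatic carbon. The entering group is 3-(dimethylamino)pyrrolidin-1-yl. For the measured compounds named here, only one measured step bears on this, a swap on the same aromatic carbon, which gave a number 0.3 percentage points lower from compound 1 to compound 2 (within the scatter). One step is thin evidence, but it points to no expected change beyond the scatter, and the estimated step is a number 1.1 percentage points lower from compound 2 to compound 3 (within the scatter). For compound 3 the expected value in this assay is 37%, with an estimated range of 22% to 52%.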

Compound 3, percent of the compound remaining: 4.55%
Estimate against measurement, compound 3: 32.5 percentage points above, and the stated range ends above it.
By their numbers in this assay, from the lowest: compound 3; then compounds 2 and 1 (each within the scatter of the next).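

The group on this aromatic carbon can matter greatly for stability: in this assay, 3-(dimethylamino)pyrrolidin-1-yl gives a number 33.6 percentage points lower from compound 2 to compound 3 (beyond the scatter) and also a number 33.9 percentage points lower from compound 1 to compound 3 (beyond the scatter), although the earlier swap at this place stayed within the scatter. Nothing available on these compounds explains this loss. Still open, on these data alone, is whether the two methyl groups on the amine or the five-membered ring goes with the drop. A 3-aminopyrrolidin-1-yl group and a 4-(dimethylamino)piperidin-1-yl group on the same carbon would separate those two features.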